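The source may hold more compounds than are shown below. What is called first, only, known or untested is meant among the compounds shown, and "the series" means these compounds.

Compound 3, with structure `Fc1ccccc1Cn1cc(CSC(=S)N2CCNCC2)nn1`, gives 56200 nM in a functional assay on PC-3 cells (Homo sapiens) for inhibition, read by MTT assay, with a stated time of 72 h; a higher number here means a weaker inhibitor, a lower number a stronger inhibitor. Among the two numbers available it is the lowest, though compound 2, with structure `O=C(OCc1ccccc1)N1CCN(C(=S)SCc2cn(Cc3ccccc3F)nn2)CC1`, gives 68300 nM in this assay, and the step of a 1.2-fold lower number from compound 2 to compound 3 (0.08 log units; within the scatter) lies within the scatter. Compound 1, with structure `Fc1ccc(Cn2cc(CSC(=S)N3CCNCC3)nn2)cc1`, reports only a limit in this assay, > 128000 nM. Among the measured compounds shown here, the step of an at least 2.2-fold lower number from compound 1 to compound 3 (0.35 log units; beyond the scatter) is the only measured change at the same place as the one considered here, and it went toward a stronger inhibitor when the 2-fluorophenyl replaced the 4-fluorophenyl.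

Compound 4, with structure `S=C(SCc1cn(Cc2ccc(Cl)cc2)nn1)N1CCNCC1`, has not been measured. It differs from compound 3 in one place: 4-chlorophenyl in place of 2-fluorophenyl on a saturated chain carbon bound to an aromatic nitrogen. This reverses the kind of change seen in the step from compound 1 to compound 3, returning to a group on the same ring position, though with chlorine rather than fluorine. A step back toward a weaker inhibitor is therefore expected, of a size near a 1.7-fold higher number from compound 3 to compound 4 (0.23 log units; within the scatter). Compound 4 is estimated to give 95000 nM in this assay, within a range from 40000 nM to 220000 nM, with a real chance that only a limit is reported.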

Compound 4, half-maximal inhibitory concentration: > 128000 nM
Compound 4: only a limit was reported; the forecaster's own chance of this, stated with the estimate: 35%; at least 1.3-fold (0.12 log units) between middle value and limit.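

In this assay, there is an at least 2.2-fold higher number from compound 3 to compound 4 (0.35 log units; beyond the scatter), so 4-chlorophenyl on this saturated chain carbon does not keep the modest inhibition seen with 2-fluorophenyl. Compound 1, with 4-fluorophenyl, and compound 4, with 4-chlorophenyl, now both stand on the weaker side of compound 3, a pattern that rests on these three compounds only. Whether chloro and fluoro differ on this aromatic carbon cannot be read, since compound 1 and compound 4 each give only a limit, not a number: the limit of > 128000 nM in this assay, at which 2 of the 4 values shown sit.

The compounds shown leave open whether the gain in compound 3 belongs to fluorine or to where the halogen sits on the ring. They also leave open how a phenyl group with no halogen, or one carrying a methoxy group, would behave at this place.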